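Solubility notes: carboxyphenyl in place of the carboxyindole arm

The source may hold more compounds than are shown below. What is called first, only, known or untested is meant among the compounds shown, and "the series" means these compounds.

Measured so far in a physicochemical assay for solubility, read by HPLC, with a stated time of 24 h, at pH 7; a higher number here means a more soluble compound, a lower number a less soluble compound:
compound 1 `O=C(O)c1ccc2c(CN3CCC[C@H](O[C@H](CO)c4cc(Cl)cc(Cl)c4)[C@@H]3c3ccccc3)c[nH]c2c1` gives 128000 nM
compound 2 `COC(=O)Nn1c(C[C@H]2CCC[C@H](OCc3cc(C(F)(F)F)cc(C(F)(F)F)c3)[C@@H]2c2ccccc2)n[nH]c1=O` gives 154000 nM
compound 3 `OC[C@@H](O[C@H]1CCCN(Cc2cccc3nonc23)[C@H]1c1ccccc1)c1cc(Cl)cc(Cl)c1` gives 154000 nM

Compound 1 carries the lowest of the three numbers, but compound 2 and compound 3 each sit within the scatter of it, so the three are not separated in this assay. Among the compounds with values here, the one step that can be counted within the set is a 1.2-fold higher number from compound 1 to compound 3 (0.08 log units; within the scatter): a whole arm on the saturated chain carbon bound to the ring amine nitrogen was exchanged and the number did not move beyond the scatter.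

Compound 4 `O=C(O)c1ccc(CN2CCC[C@H](O[C@H](CO)c3cc(Cl)cc(Cl)c3)[C@@H]2c2ccccc2)cc1` differs from compound 1 in the same place: 4-carboxyphenyl in place of 6-carboxy-1H-indol-3-yl on a saturated chain carbon bound to an amine nitrogen in a ring. The step from compound 1 to compound 3 is the only measured one that bears on it, since it also replaces the arm on that carbon, and it was flat. Compound 2, on another core, merely shows that the same range recurs. The carboxylic acid is kept in compound 4, so nothing in the data argues for a shift in either direction; the expected step is a 1.2-fold higher number from compound 1 to compound 4 (0.07 log units; within the scatter), none beyond the scatter. Compound 4 is therefore estimated at 150000 nM, with a range from 60000 nM to 350000 nM.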

Compound 4, solubility: 85000 nM
Compound 4: middle estimate off by 1.8-fold (0.25 log units), on the high side, within the range that was stated.
By their numbers in this assay, from the lowest: compounds 4, 1, 2 and 3 (each within the scatter of the next).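

The arm on a saturated chain carbon bound to an amine nitrogen in a ring can now be reduced to a single six-membered aromatic ring of carbon only: in this assay the change to 4-carboxyphenyl gives a 1.5-fold lower number from compound 1 to compound 4 (0.18 log units; within the scatter) and so removes the five-membered aromatic ring and one hydrogen-bond donor without a step beyond the scatter. Set against the arm of compound 3, which has two rings and no carboxylic acid, the same 4-carboxyphenyl arm gives a 1.8-fold lower number from compound 3 to compound 4 (0.26 log units; within the scatter) and this step also stays within the scatter, so the three arms on the shared core are not separated and the position has so far shown no measurable dependence on the arm. No measurement at hand explains this flat result or ties it to any feature of the arms.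

Still open, as far as these compounds go, is whether the flat picture holds for an arm of a different kind, such as a phenyl ring carrying an aminomethyl group in place of the carboxylic acid or a carboxylic acid on a longer chain. The compounds shown also leave open whether a plain phenyl arm with neither group would stay in the same range.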